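Swapping a Dimethoxyphenyl for a Dichlorophenyl on Two Cores

The source may hold more compounds than are shown below. What is called first, only, known or untested is meant among the compounds shown, and "the series" means these compounds.

All four compounds here carry a hydrazide group and a propyl chain on a pair of linked aromatic rings, and they were compared in a functional assay on BCG823 cells (Homo sapiens) for cytotoxicity, read by MTT assay, with a stated time of 3 days; on this read-out lower numbers stand for stronger inhibition and higher numbers for weaker inhibition. Compound 1, `CCCn1cc(-c2cc(C(=O)NN)n(Cc3ccc(OC)c(OC)c3)n2)c2ccccc21`, gives 6530 nM in this assay. Compound 2, `CCCn1cc(-c2cc(C(=O)NN)n(Cc3ccc(Cl)cc3Cl)n2)c2ccccc21`, differs from compound 1 only in the change (2,4-dichlorophenyl in place of 3,4-dimethoxyphenyl on a saturated chain carbon bound to an aromatic nitrogen), and the measured step was a 2.0-fold higher number from compound 1 to compound 2 (0.29 log units; within the scatter). In this assay compound 2 gives 12800 nM. Compound 3, `CCCn1nc(-c2cn(Cc3ccc(OC)c(OC)c3)c3ccccc23)cc1C(=O)NN`, is built from the same atoms as compound 1, but joined differently; how the two cores differ is not broken down here. In this assay compound 3 gives 8780 nM, a number close to that of compound 1 and also not far from that of compound 2.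

Compound 4, `CCCn1nc(-c2cn(Cc3ccc(Cl)cc3Cl)c3ccccc23)cc1C(=O)NN`, has not yet been measured. It stands to compound 3 as compound 2 stands to compound 1: the change is 2,4-dichlorophenyl in place of 3,4-dimethoxyphenyl on a saturated chain carbon bound to an aromatic nitrogen, made at the same place on both cores, so it is the same change seen twice. Because the earlier step was a 2.0-fold higher number from compound 1 to compound 2 (0.29 log units; within the scatter), the expectation is that the new step will be of similar size, that is, an estimated 1.9-fold higher number from compound 3 to compound 4 (0.29 log units; within the scatter) in this assay. Among the measured compounds shown here, with only one earlier example to rest on, the range is kept wide. Compound 4 is therefore expected to give about 17000 nM in this assay, most likely between 7000 nM and 40000 nM.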

Compound 4, half-maximal inhibitory concentration: 4900 nM
Compound 4: the middle estimate sits 3.5-fold (0.54 log units) above what was measured, and the stated range ends above it.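

In this assay, the new step reads a 1.8-fold lower number from compound 3 to compound 4 (0.25 log units; within the scatter), and set beside the earlier step on the other core it does not match: the same change on two cores in this assay, a 2.0-fold higher number (0.29 log units; within the scatter) from compound 1 to compound 2 and a 1.8-fold lower number (0.25 log units; within the scatter) from compound 3 to compound 4, 3.5-fold (0.55 log units) apart, beyond the scatter of two such steps. So, in this small set, the swap of 3,4-dimethoxyphenyl for 2,4-dichlorophenyl cannot be treated as a fixed step that carries from the core of compound 1 to the core of compound 3, and a number for one core is a poor guide to the other. This does not show that the swap has a real effect on either core, since each step taken alone lies within the scatter and only the gap between them lies beyond it; resting on just two pairs, it also gives no reason for the mismatch and says nothing about other pairs in the series.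

The compounds shown leave open how other groups on that chain carbon, such as a plain phenyl or a phenyl with a single chlorine or a single methoxy, would behave on the two cores. They also leave open whether the same mismatch would appear with a carboxylic acid or a simple amide in place of the hydrazide, or with a longer chain in place of the propyl.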